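The source may report more compounds than this note shows. Statements on the series, on what has been measured and on what is new or still open speak of the compounds shown alone.

For the measured compounds named here, the three compounds measured so far share one core and differ only in the group on the six-membered aromatic ring. Compound 1 `Cc1[nH]c2ccc(Br)cc2c1C1=CCNCC1` gives 480 nM in an assay on isolated protein for displacement of a labelled ligand from 5-hydroxytryptamine receptor 7 (Homo sapiens); on this read-out higher numbers stand for weaker inhibition and lower numbers for stronger inhibition. Compound 2 `Cc1[nH]c2ccc(F)cc2c1C1=CCNCC1` gives 3100 nM in this assay, and compound 3 `Cc1[nH]c2ccc(OS(=O)(=O)C(F)(F)F)cc2c1C1=CCNCC1` gives 1800 nM in this assay. Among these three numbers compound 3 holds the second highest: its distance to compound 2 stays within the scatter, shown by the step of a 1.7-fold lower number from compound 2 to compound 3 (0.24 log units; within the scatter), while its distance to compound 1 goes beyond it, shown by the step of a 3.8-fold higher number from compound 1 to compound 3 (0.57 log units; beyond the scatter). The path to compound 4 `Cc1[nH]c2ccc(-c3ccsc3)cc2c1C1=CCNCC1` alters that same place once more: thiophen-3-yl in place of ((trifluoromethyl)sulfonyl)oxy on an aromatic carbon. The measured steps that touch this place are a 6.5-fold higher number from compound 1 to compound 2 (0.81 log units; beyond the scatter) and a 3.8-fold higher number from compound 1 to compound 3 (0.57 log units; beyond the scatter), both modest and both beyond the scatter; neither of the two groups that replaced bromo reached the number of compound 1. Going by the values given here, no measured step exchanges ((trifluoromethyl)sulfonyl)oxy for an aromatic ring, so no measured step fixes the direction. Compound 4 is therefore expected to fall within the spread already seen, with an estimated value of 1000 nM in this assay and a range from 300 nM to 3500 nM. That expectation corresponds to an estimated step of a 1.8-fold lower number from compound 3 to compound 4 (0.26 log units; within the scatter).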

Compound 4, half-maximal inhibitory concentration: 690 nM
Estimate against measurement, compound 4: 1.4-fold (0.16 log units) above; low and high end bracket the measured number.
By their numbers in this assay, from the lowest: compounds 1 and 4 (each within the scatter of the next); then compounds 3 and 2 (each within the scatter of the next).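

In this assay, for the compounds shown here, thiophen-3-yl is the first replacement for bromo at this aromatic carbon to stay within the scatter, with a 1.4-fold higher number from compound 1 to compound 4 (0.16 log units; within the scatter), whereas the fluoro and ((trifluoromethyl)sulfonyl)oxy replacements both went beyond it. The same change also separates thiophen-3-yl from those two groups, which lie within the scatter of each other, with a 2.6-fold lower number from compound 3 to compound 4 (0.42 log units; beyond the scatter) and a 4.5-fold lower number from compound 2 to compound 4 (0.65 log units; beyond the scatter), both modest and beyond the scatter. Among these four compounds, then, this place carries a five-membered aromatic ring with no change beyond the scatter from bromo, so the outcome here does not simply follow from replacing bromo with something else. No available evidence bears on why the thiophen-3-yl group behaves this way.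

The compounds shown leave open whether a phenyl ring, a pyridine ring or a morpholine group at this aromatic carbon would give a number clearly lower than that of compound 1. They also leave open whether a methoxy group or a nitrile here would stay with bromo and thiophen-3-yl or fall with fluoro and ((trifluoromethyl)sulfonyl)oxy.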